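One fluoro group leaves compound 2

The compounds below may be only part of what the source reports. "The series", "measured", "known", "first", "only" and "open" are said of these compounds alone.

In a physicochemical assay for lipophilicity, using the shake flask method, measured as octanol-water partition, with a stated time of 30 min, at pH 7.4 (on this read-out lower numbers stand for lower lipophilicity and higher numbers for higher lipophilicity), compound 1 (`COc1nn(-c2ccccn2)c2cc(-c3ccc(CCC(=O)O)cc3)ccc12`) gives 3.3 and compound 2 (`COc1nn(-c2ccccn2)c2cc(-c3ccc([C@H]4C[C@@H]4C(=O)O)cc3)cc(F)c12`) gives 3.8 as the higher of the two numbers, a gap beyond the usual scatter. Compound 3 (`COc1nn(-c2ccccn2)c2cc(-c3ccc([C@H]4C[C@@H]4C(=O)O)cc3)ccc12`) differs from compound 2 by hydrogen in place of fluoro on an aromatic carbon. Among the compounds with values here, no measured pair isolates this change, so only a small fall is expected in this assay, perhaps no larger than the usual scatter, and the estimate is a number 0.20 log units lower from compound 2 to compound 3 (within the scatter) for this step. For compound 3 the estimated value is 3.6 with an expected range from 3.2 to 3.9 in this measurement.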

Compound 3, distribution coefficient: 3.8
Estimate against measurement, compound 3: 0.20 log units below; the range from low to high includes it.
By their numbers in this assay, from the lowest: compound 1; then compounds 2 and 3 (each within the scatter of the next).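

In this assay, hydrogen in place of fluoro on this aromatic carbon gives no change at the digits printed from compound 2 to compound 3 (within the scatter), so fluoro and hydrogen cannot be told apart here on this read-out. With the fluoro group gone, the side chain stands as the one difference: 2-carboxycyclopropyl in place of 2-carboxyethyl gives a number 0.50 log units higher from compound 1 to compound 3 (beyond the scatter). Nothing measured here offers an explanation for either step. On these data alone, whether chloro or methoxy on this aromatic carbon would behave like fluoro remains open. So does whether the side-chain step would hold with an amide in place of the carboxylic acid.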